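A phenyl group added to compound 3

The compounds below may be only part of what the source reports. "The series", "measured", "known", "first", "only" and "open" are said of these compounds alone.

Measured in a functional assay on Raji cells (Homo sapiens) for cytotoxicity, read by CCK-8 assay, with a stated time of 24 h; on this read-out lower numbers stand for stronger inhibition and higher numbers for weaker inhibition:
- Compound 1 `C=CC(=O)N1C(=O)CC(c2ccc(C(F)(F)F)cc2)Sc2ccccc21`: 47600 nM
- Compound 2 `C=CC(=O)N1C(=O)CC(c2ccc(C)cc2)Sc2ccccc21`: 75500 nM
- Compound 3 `C=CC(=O)N1C(=O)CCSc2ccccc21`: 581000 nM

Compound 3 has the highest number of the three, making it the weakest here. Compound 4 `C=CC(=O)N1C(=O)CC(c2ccccc2)Sc2ccccc21` differs from it by phenyl in place of hydrogen on a saturated ring carbon. Within the data shown here, the closest precedent is a 7.7-fold higher number from compound 2 to compound 3 (0.89 log units; beyond the scatter), where hydrogen replaces 4-methylphenyl. Read in reverse, it points to a lower number of similar size for compound 4. The other measured step, a 1.6-fold higher number from compound 1 to compound 2 (0.20 log units; within the scatter), changes only the group carried on that aromatic ring, so the missing methyl should matter little. The expected step is a 7.7-fold lower number from compound 3 to compound 4 (0.89 log units; beyond the scatter) in this assay. For compound 4 the estimate is 75000 nM, with an expected range from 38000 nM to 150000 nM.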

Compound 4, half-maximal inhibitory concentration: 74100 nM
Estimate against measurement, compound 4: 1.0-fold (0.01 log units) above; measured number inside the range.
By their numbers in this assay, from the lowest: compounds 1, 4 and 2 (each within the scatter of the next); then compound 3.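

In this assay, the plain phenyl ring on the saturated ring carbon next to the ring sulfur is enough on its own for the step of a 7.8-fold lower number from compound 3 to compound 4 (0.89 log units; beyond the scatter). Methyl and trifluoromethyl on that phenyl ring make no readable difference: a 1.0-fold lower number from compound 2 to compound 4 (0.01 log units; within the scatter) and a 1.6-fold higher number from compound 1 to compound 4 (0.19 log units; within the scatter) both stay within the scatter. Nothing available explains why the phenyl ring matters. Still open, as far as these compounds go, is whether an amine or a carboxylic acid on the phenyl ring would behave like methyl and trifluoromethyl, and whether a simple ethyl chain at that ring carbon could replace the phenyl ring.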